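The source may report more compounds than this note shows. Statements on the series, on what has been measured and on what is new or still open speak of the compounds shown alone.

Measured compounds:
Compound 1, `CCOC(=O)c1oc2ccc(N(Cc3ccc(Cl)cc3)S(=O)(=O)c3ccc(Cl)cc3)cc2c1C`, gives 9640 nM in a functional assay on HCT-116 cells (Homo sapiens) for inhibition, read by MTT assay, with a stated time of 72 h; on this read-out higher numbers stand for weaker inhibition and lower numbers for stronger inhibition.
Compound 2, `Cc1c(C(=O)NCCCn2ccnc2)oc2ccc(N(Cc3ccccc3)S(=O)(=O)c3ccc(Cl)cc3)cc12`, gives 5000 nM in this assay.

Compound 2 stands next to compound 1: the two numbers lie within the usual scatter of each other, so the data do not separate them. Both compounds share a core carrying a sulfonamide built from a 4-chlorophenyl group and a benzyl-type group; compound 1 carries an ester on the core, compound 2 an amide with a propyl chain bearing an imidazole.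

Compound 3, `Cc1c(C(=O)NCCCn2ccnc2)oc2ccc(N(Cc3ccc(Cl)cc3)S(=O)(=O)c3ccc(Cl)cc3)cc12`, is compound 2 with one change: chloro in place of hydrogen on an aromatic carbon. For the measured compounds named here, the same change appears, together with the ester-to-amide difference, when compound 1 is set beside compound 2, but no pair of measured compounds differs in this chloro alone, so its effect on this assay has not been isolated. The expectation for this assay is therefore a step from compound 2 to compound 3 of no more than the scatter, in no clear direction, as in a 1.1-fold lower number from compound 2 to compound 3 (0.05 log units; within the scatter). Compound 3 is expected to give about 4500 nM, with a plausible range from 1500 nM to 14000 nM.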

Compound 3, half-maximal inhibitory concentration: 1890 nM
For compound 3 the middle estimate is 2.4-fold (0.38 log units) above the measured one; measured number inside the range.
By their numbers in this assay, from the lowest: compound 3; then compounds 2 and 1 (each within the scatter of the next).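

In this assay, chloro in place of hydrogen on the benzyl group, giving 4-chlorobenzyl, brings a 2.6-fold lower number from compound 2 to compound 3 (0.42 log units; beyond the scatter). For the compounds shown here, this isolates the chloro for the first time, and on this aromatic carbon, para to a large group, its step lies beyond the scatter, even though compound 1 and compound 2, which differ in two places at once, could not be separated. With the 4-chlorobenzyl group held constant, (3-(1H-imidazol-1-yl)propyl)amino in place of ethoxy on the carbonyl carbon brings a 5.1-fold lower number from compound 1 to compound 3 (0.71 log units; beyond the scatter), so this change also lowers the number when seen alone, and the two changes had been hidden in the earlier comparison.

No measurement shown here accounts for either step.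

Going by these compounds, it remains open whether fluoro, bromo or methyl at the same place on the benzyl ring would match the chloro, or whether the chloro itself is needed there. On these data alone, it is equally open how much of the amide step belongs to the imidazole ring and how much to the chain, which a simple dimethylamino group or a longer chain at the end of the amide could begin to separate.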